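A few compounds are considered here, and "the series" means these few. Any claim that something is new, unique, unknown or untested is made for them only; others in the source may bear on it.

Compounds measured in a functional assay on HL-60 cells (Homo sapiens) for antiproliferative activity, read by MTT assay, with a stated time of 48 h; a higher number here means a weaker inhibitor, a lower number a stronger inhibitor:

Compound 1 `CCn1c(N)c(-c2nc3ccccc3[nH]2)c2nc(C#N)c(C#N)nc21` — in this assay compound 1 gives > 50000 nM, which is a limit of the assay rather than a number.
Compound 2 `CN(C)CCn1c(N)c(-c2nc3ccccc3[nH]2)c2nc(C#N)c(C#N)nc21` — in this assay compound 2 gives 2220 nM.
Compound 3 `CCCn1c(N)c(-c2nc3ccccc3[nH]2)c2nc(C#N)c(C#N)nc21` — in this assay compound 3 gives 45200 nM.

Among the two compounds with a number, compound 3 has the highest one; its nearest neighbour is compound 2, and the step of a 20-fold higher number from compound 2 to compound 3 (1.31 log units; beyond the scatter) is a large one. The step of an at least 1.1-fold lower number from compound 1 to compound 3 (0.04 log units; that floor lies within the scatter) is small and sits within the scatter. The step of an at least 22-fold lower number from compound 1 to compound 2 (1.35 log units; beyond the scatter) is large, and compound 1 there gives only (the limit of > 50000 nM in this assay, at which 1 of the 3 values shown sits).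

Compound 4 `N#Cc1nc2c(-c3nc4ccccc4[nH]3)c(N)n(CCCNc3ccccc3)c2nc1C#N` has not yet been measured. Compared with compound 3, the change is anilino in place of hydrogen on a saturated chain carbon, three bonds along the chain from an aromatic nitrogen. The measured steps that bear on it are those that put a nitrogen-bearing group onto the same chain: an at least 22-fold lower number from compound 1 to compound 2 (1.35 log units; beyond the scatter) and, in the reverse sense, a 20-fold higher number from compound 2 to compound 3 (1.31 log units; beyond the scatter). Both were large, and both point to a lower number when such a group is present on the chain. The anilino group enters one bond further out than the dimethylamino group did, so the size of the step is uncertain, but a lower number beyond the scatter is expected. The expected step is a 9.0-fold lower number from compound 3 to compound 4 (0.96 log units; beyond the scatter), which gives an estimate for compound 4 of 5000 nM, with a range from 1200 nM to 25000 nM.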

Compound 4, half-maximal inhibitory concentration: 6920 nM
Beside the measured number, compound 4's estimate is 1.4-fold (0.14 log units) below it, and the stated range covers the measured number.
By their numbers in this assay, from the lowest: compound 2; then compound 4; then compound 3. At a limit, above all of these: compound 1.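

In this assay, the 3-anilinopropyl chain gives a 6.5-fold lower number from compound 3 to compound 4 (0.82 log units; beyond the scatter), so compound 4 shows that a chain nitrogen can lower the number when it carries a benzene ring and stands further along the chain, not only as the dimethylamino group of compound 2. The change does not match that earlier group, however, as there is a 3.1-fold higher number from compound 2 to compound 4 (0.49 log units; beyond the scatter), so the two nitrogen-bearing chains differ clearly and compound 2 remains the lowest number of those shown. The reading an at least 7.2-fold lower number from compound 1 to compound 4 (0.85 log units; beyond the scatter) is only a floor, and the true step could be larger, since compound 1 is the one compound that sits at a limit rather than at a number: the limit of > 50000 nM in this assay, at which 1 of the 4 values shown sits.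

The compounds shown leave open whether the step to compound 4 comes from the chain nitrogen or from the benzene ring, a question that a 3-phenylpropyl chain, which has the ring without the nitrogen, would help to settle. A 3-(dimethylamino)propyl chain would also be needed to separate the effect of the group on the end of the chain from that of the chain's length.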